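The source may report more compounds than this note shows. Statements on the series, on what has been measured and on what is new or still open speak of the compounds shown alone.

Of the compounds shown here, three sharing one core have been tested in an assay on isolated protein for inhibition of Maltase-glucoamylase (Homo sapiens), with a stated time of 15 min; on this read-out lower numbers stand for stronger inhibition and higher numbers for weaker inhibition. Compound 1 `O=C(N/N=C/c1cccc(O)c1O)c1ccc(-c2nc3ccccc3s2)cc1` gives 11200 nM. Compound 2 `COc1ccc(/C=N/NC(=O)c2ccc(-c3nc4ccccc4s3)cc2)cc1` gives 18300 nM. Compound 3 `O=C(N/N=C/c1ccc(Cl)cc1)c1ccc(-c2nc3ccccc3s2)cc1` gives 5310 nM, the lowest of the three numbers: the step of a 2.1-fold lower number from compound 1 to compound 3 (0.32 log units; beyond the scatter) and the step of a 3.4-fold lower number from compound 2 to compound 3 (0.54 log units; beyond the scatter) both lie beyond the scatter, while the step of a 1.6-fold higher number from compound 1 to compound 2 (0.21 log units; within the scatter) does not.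

Compound 4 `O=C(N/N=C/c1cccc(O)c1)c1ccc(-c2nc3ccccc3s2)cc1` differs from compound 3 in one place: 3-hydroxyphenyl in place of 4-chlorophenyl on a carbon with a double bond to nitrogen. Among the compounds with values here, the step that bears most directly on this change is the one from compound 1 to compound 3, where a hydroxyl-bearing phenyl was exchanged for the 4-chlorophenyl and the number fell by a modest amount. Moving from compound 3 to compound 4 reverses that direction, putting a hydroxyl-bearing phenyl back in place of the chlorine, though with a single hydroxyl rather than two. The expectation is therefore a modest rise in this assay, roughly the size seen between compounds 1 and 3, and in the reverse direction, so that compound 4 is expected to show a step of a 1.8-fold higher number from compound 3 to compound 4 (0.25 log units; within the scatter). Compound 4 is estimated to give 9500 nM, with a range from 4000 nM to 25000 nM.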

Compound 4, half-maximal inhibitory concentration: 9210 nM
The estimate for compound 4 lay 1.0-fold (0.01 log units) above the measured number, within the range that was stated.
By their numbers in this assay, from the lowest: compounds 3, 4, 1 and 2 (each within the scatter of the next, the first and the last beyond it).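

In this assay, the 3-hydroxyphenyl on the carbon with a double bond to nitrogen cannot be told apart from the 4-chlorophenyl, with a 1.7-fold higher number from compound 3 to compound 4 (0.24 log units; within the scatter), whereas the 2,3-dihydroxyphenyl of compound 1 could be, with a 2.1-fold lower number from compound 1 to compound 3 (0.32 log units; beyond the scatter). Removing one hydroxy from compound 1 also gives no clear change, with a 1.2-fold lower number from compound 1 to compound 4 (0.08 log units; within the scatter), and replacing the 4-methoxyphenyl gives a 2.0-fold lower number from compound 2 to compound 4 (0.30 log units; within the scatter), so compound 4 lies within the scatter of all three earlier compounds, even though compound 2 and compound 3 are separated by more than the scatter. The data shown offer no measurement that explains these results.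

The chloro of compound 3 and the hydroxy of compound 4 differ in both identity and ring position, so these compounds cannot separate the effect of the group from the effect of where it sits. On these data alone, it also remains open whether an amine or a carboxylic acid on this phenyl ring would move the number beyond the scatter in either direction.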